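A few compounds are considered here, and "the series" means these few. Any claim that something is new, unique, unknown or untested is made for them only; others in the source may bear on it.

Compound 1 `C=CCn1c(SCC(=O)Nc2ccc(C(C)=O)cc2)nnc1-c1ccccc1` gives 54% in a functional assay on the whole organism (strain albino) for inhibition, with Rattus norvegicus as the target, read by paw edema, with stated times of 30 min and 3 h, at a dose of 0.28 mmol/kg by the oral route; on this read-out lower numbers stand for less inhibition and higher numbers for more inhibition at the one dose given (going by the name of the read-out). Compound 2 `C=CCn1c(SCC(=O)Nc2ccc(/C(C)=N/O)cc2)nnc1-c1ccccc1` gives 73%. Compound 3 `C=CCn1c(SCC(=O)Nc2ccc(C(C)=O)cc2)nnc1-c1ccc(OC)cc1` gives 52%.

Compound 1 stands second highest of these three numbers. Its nearest neighbour is compound 3, whose value lies within the scatter of compound 1, so the two cannot be told apart. Compound 2 is further away: a number 19 percentage points higher from compound 1 to compound 2 (beyond the scatter).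

Compound 4 `CCn1c(SCC(=O)Nc2ccc(C(C)=O)cc2)nnc1-c1ccccc1` differs from compound 1 by methyl in place of vinyl on a saturated chain carbon bound to an aromatic nitrogen. Neither measured step touches this part of the molecule: a number 19 percentage points higher from compound 1 to compound 2 (beyond the scatter) and a number 2 percentage points lower from compound 1 to compound 3 (within the scatter) both changed groups on an aromatic carbon, far from the chain bound to the aromatic nitrogen. Among the compounds with values here, no step therefore bears directly on this change, and a step of no size beyond the scatter is expected in this assay.

For compound 4 the expected value is 50%, ranging from 36% to 64%, which means an estimated a number 4 percentage points lower from compound 1 to compound 4 (within the scatter).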

Compound 4, a percentage reported as inhibition, in the whole organism at one dose (the size of the read-out at that dose, not a potency): 56%
For compound 4 the middle estimate is 6 percentage points below the measured one; measured number inside the range.
By their numbers in this assay, from the lowest: compounds 3, 1 and 4 (each within the scatter of the next); then compound 2.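

The chain on the aromatic nitrogen is a new place tested here: in this assay, methyl in place of vinyl gives a number 2 percentage points higher from compound 1 to compound 4 (within the scatter). In this pair, then, the double bond of the allyl chain is not needed to keep the inhibition at this level. Nothing measured on these compounds gives a reason for this result.

As far as these compounds go, it remains open whether a longer chain, a benzyl group or an amine at this place would also leave the number unchanged. From the compounds shown here alone, whether ethyl would give the same result alongside the change that separates compound 2 from compound 1 also remains open.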